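Swapping the bromoindole for a hydroxyphenyl group

This account rests on a few compounds, and the source may have more. Where it says the series, first, only, none or still open, it means among the compounds named here.

- compound 1 `Cc1ccc(CS/C(=C/c2ccc(O)cc2)C(=O)c2ccc(Cl)cc2)cc1`: 10000 nM
- compound 2 `COc1ccccc1/C=C(/SCc1ccc(F)cc1)C(=O)c1ccc(Cl)cc1`: 10000 nM
- compound 3 `O=C(/C(=C\c1c[nH]c2ccc(Br)cc12)SCc1ccc(F)cc1)c1ccc(Cl)cc1`: 50000 nM

In a functional assay on DU-145 cells (Homo sapiens) for inhibition, read by trypan blue exclusion, with a stated time of 96 h (on this read-out lower numbers stand for stronger inhibition of growth and higher numbers for weaker inhibition of growth), compound 3 gives 50000 nM, the highest of the three numbers, so it sits at the weak end of this small set. The next compound, compound 4 `O=C(/C(=C\c1ccc(O)cc1)SCc1ccc(F)cc1)c1ccc(Cl)cc1`, makes a single change: 4-hydroxyphenyl in place of 5-bromo-1H-indol-3-yl on a double-bonded chain carbon bound to a double-bonded chain carbon. In words, 4-hydroxyphenyl comes in place of 5-bromo-1H-indol-3-yl on a double-bonded chain carbon bound to a double-bonded chain carbon.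

For the measured compounds named here, only one measured step touches this place: a 5.0-fold higher number from compound 2 to compound 3 (0.70 log units; beyond the scatter). That step brought in the same 5-bromo-1H-indol-3-yl group and was modest, and compound 2 differs from compound 4 only at this place. Compound 1 already carries 4-hydroxyphenyl there and gives 10000 nM, although it differs from compound 4 elsewhere in the molecule. Both comparisons suggest that losing the 5-bromo-1H-indol-3-yl group should bring the number down, by about as much as that one step raised it. One step is thin evidence, so the range stays wide. In this assay the expected change is a 5.0-fold lower number from compound 3 to compound 4 (0.70 log units; beyond the scatter), towards stronger inhibition of growth. For compound 4 the estimated value is 10000 nM, with an expected range from 3500 nM to 30000 nM.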

Compound 4, concentration for 50% growth inhibition: 25000 nM
Beside the measured number, compound 4's estimate is 2.5-fold (0.40 log units) below it, within the range that was stated.
By their numbers in this assay, from the lowest: compounds 1 and 2 (each within the scatter of the next); then compounds 4 and 3 (each within the scatter of the next).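

In this assay, 4-hydroxyphenyl in place of 5-bromo-1H-indol-3-yl gives a 2.0-fold lower number from compound 3 to compound 4 (0.30 log units; within the scatter), so this change does not clearly separate the two groups, even though 4-hydroxyphenyl has fewer heavy atoms and no bromine. The 2-methoxyphenyl group now stands apart from both: 4-hydroxyphenyl in its place gives a 2.5-fold higher number from compound 2 to compound 4 (0.40 log units; beyond the scatter), a modest step in the same direction as a 5.0-fold higher number from compound 2 to compound 3 (0.70 log units; beyond the scatter), so among these three groups at this place, only 2-methoxyphenyl goes with the lower number. Elsewhere in the molecule, with 4-hydroxyphenyl held fixed, fluoro in place of methyl on an aromatic carbon gives a 2.5-fold higher number from compound 1 to compound 4 (0.40 log units; beyond the scatter), which shows that the number also responds to a change away from this place, by a step of the same printed size.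

Nothing among the data shown explains why these numbers move as they do. Going by these compounds, it also remains open whether an amine or a carboxylic acid on a double-bonded chain carbon bound to a double-bonded chain carbon would give a number clearly different from those of these aromatic groups.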